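The source may hold more compounds than are shown below. What is called first, only, known or untested is meant among the compounds shown, and "the series" means these compounds.

Measured in a functional assay on HT-29 cells (Homo sapiens) for inhibition, read by MTT assay; a lower number here means a stronger inhibitor, a higher number a weaker inhibitor:
Compound 1 `COc1ccc(/C=C2\c3cc(OC)c(OC)c(OC)c3CC[C@@H]2O)cc1F`: 3 nM
Compound 2 `COc1ccc(/C=C2\c3cc(OC)c(OC)c(OC)c3CC[C@@H]2O)cc1C#N`: 5 nM
Compound 3 `COc1ccc(/C=C2\c3cc(OC)c(OC)c(OC)c3CC[C@H]2O)cc1C#N`: 200 nM

Compound 3 has the highest number of the three, 200 nM, which makes it the weakest inhibitor in this small set. Its distance from its closest relative is a 40-fold higher number from compound 2 to compound 3 (1.60 log units; beyond the scatter). That gap can be tied to the stereocentre alone, given (the fact that compounds 2 and 3 differ only in the configuration as drawn).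

Compound 4 `COc1ccc(/C=C2\c3cc(OC)c(OC)c(OC)c3CC[C@H]2O)cc1C` keeps the drawn configuration of compound 3 and changes one group, with methyl in place of cyano on an aromatic carbon.

Within the data shown here, only one measured step touches this aromatic carbon, and it is small: a 1.7-fold higher number from compound 1 to compound 2 (0.22 log units; within the scatter). As far as these compounds go, it swaps fluoro for cyano, so methyl itself remains untested. Among the measured compounds shown here, with that step as the only guide, no shift beyond the scatter is expected in this assay, and the expected step is no change at the digits printed from compound 3 to compound 4 (within the scatter). For compound 4 the estimated value is 200 nM, with an expected range of 80 nM to 500 nM.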

Compound 4, half-maximal inhibitory concentration: 3970 nM
The estimate for compound 4 lay 20-fold (1.30 log units) below the measured number, and the stated range ends below it.
By their numbers in this assay, from the lowest: compounds 1 and 2 (each within the scatter of the next); then compound 3; then compound 4.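

The aromatic carbon ortho to a methoxy group is not indifferent to what it carries: in this assay, methyl in place of cyano gives a 20-fold higher number from compound 3 to compound 4 (1.30 log units; beyond the scatter). Among these compounds, the only earlier step at this carbon, a 1.7-fold higher number from compound 1 to compound 2 (0.22 log units; within the scatter), exchanges fluoro for cyano on the other drawn configuration of the stereocentre, so a step within the scatter for that pair of groups did not carry over to the pair seen here. Nothing given here accounts for the size of this new step.

The compounds shown leave open whether methyl would produce a step of similar size on the configuration of compound 2. Also open, as far as these compounds go, is where an amine, a chloro group or a longer chain at this carbon would fall relative to cyano and methyl.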